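Extending a Methyl to Ethyl on a Potent Antifolate Chain

The source may hold more compounds than are shown below. What is called first, only, known or untested is meant among the compounds shown, and "the series" means these compounds.

Compound 1 `Nc1nc(N)c2nc(CCc3ccc(C(=O)NC(CCCNC(=O)c4ccccc4C(=O)O)C(=O)O)cc3)cnc2n1` gives 0.53 nM in a functional assay on CCRF-CEM cells (Homo sapiens) for inhibition; a higher number here means a weaker inhibitor, a lower number a stronger inhibitor. Compound 2 `CC(Cc1cnc2nc(N)nc(N)c2n1)c1ccc(C(=O)NC(CCCNC(=O)c2ccccc2C(=O)O)C(=O)O)cc1` gives 0.63 nM; this is the higher of the two numbers, though the step of a 1.2-fold higher number from compound 1 to compound 2 (0.08 log units; within the scatter) is within the scatter. Compound 3 `CCC(Cc1cnc2nc(N)nc(N)c2n1)c1ccc(C(=O)NC(CCCNC(=O)c2ccccc2C(=O)O)C(=O)O)cc1` has not yet been measured. It differs from compound 2 by methyl in place of hydrogen on a saturated chain carbon, two bonds along the chain from an aromatic carbon, which is the same kind of small change as the one that produced a 1.2-fold higher number from compound 1 to compound 2 (0.08 log units; within the scatter). Because a 1.2-fold higher number from compound 1 to compound 2 (0.08 log units; within the scatter) was within the scatter, no step beyond the scatter is expected in this assay for compound 3, and the expected step is a 1.1-fold higher number from compound 2 to compound 3 (0.05 log units; within the scatter). Compound 3 is therefore estimated at 0.7 nM, with a range from 0.3 nM to 1.6 nM.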

Compound 3, half-maximal inhibitory concentration: 1.2 nM
For compound 3 the middle estimate is 1.7-fold (0.23 log units) below the measured one, and the stated range covers the measured number.
By their numbers in this assay, from the lowest: compounds 1, 2 and 3 (each within the scatter of the next, the first and the last beyond it).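

In this assay the move from methyl to ethyl gives a 1.9-fold higher number from compound 2 to compound 3 (0.28 log units; within the scatter) and so stays small on its own. Set against hydrogen on the same saturated chain carbon, however, ethyl gives a 2.3-fold higher number from compound 1 to compound 3 (0.35 log units; beyond the scatter) and is the first change here to pass the scatter, so this position accepts ethyl at only a modest cost. Nothing measured here gives a reason for this drift.

From the compounds shown here alone, whether a propyl group, a longer chain, or an amine on this carbon would continue the drift or break it remains open.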